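A few compounds are considered here, and "the series" means these few. Any claim that something is new, unique, unknown or untested is made for them only; others in the source may bear on it.

Compound 1 `CC(=O)N1CCN(CCN2CCC(CNC(=O)c3cccc4[nH]c(C(C)C)nc34)CC2)CC1` and compound 2 `CS(=O)(=O)N1CCN(CC(O)CN2CCC(CNC(=O)c3cccc4[nH]c(C5CC5)nc34)CC2)CC1` share a core and were compared in an assay on isolated protein for binding affinity to 5-hydroxytryptamine receptor 4 (Homo sapiens); on this read-out higher numbers stand for weaker inhibition and lower numbers for stronger inhibition. Compound 1 gives 5.01 nM, while compound 2 gives 0.501 nM, the lowest of the two numbers, its nearest neighbour being compound 1 at a gap beyond the usual scatter. Compound 3 `CC(C)(C)c1nc2c(C(=O)NCC3CCN(CC(O)CN4CCN(S(C)(=O)=O)CC4)CC3)cccc2[nH]1` has not yet been measured in this assay. It differs from compound 2 in one place: tert-butyl in place of cyclopropyl on an aromatic carbon. For the measured compounds named here, with no measured pair sharing this change, the step of a 1.6-fold higher number from compound 2 to compound 3 (0.20 log units; within the scatter) is expected to stay small, with a slight lean toward a higher number. Compound 3 is therefore estimated at 0.8 nM, within a range of 0.3 nM to 2.5 nM.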

Compound 3, inhibition constant: 12.6 nM
Estimate against measurement, compound 3: 16-fold (1.20 log units) below, outside the stated range (above it).
By their numbers in this assay, from the lowest: compound 2; then compound 1; then compound 3.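

In this assay, the aromatic carbon between two ring nitrogen atoms proves sensitive to the group it carries: tert-butyl in place of cyclopropyl gives a 25-fold higher number from compound 2 to compound 3 (1.40 log units; beyond the scatter). The exchange is small on paper, with 3 heavy atoms leaving and 4 entering and no hydrogen-bond donors or acceptors on either side, yet the step is large. Nothing at hand gives a reason for it. From the compounds shown here alone, whether an amine or a longer chain such as n-propyl here would keep the number near that of compound 2 stays open. Also open, going by these compounds, is whether the same change would give a similar step with the rest of the molecule as in compound 1.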